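A few compounds are considered here, and "the series" means these few. Any claim that something is new, unique, unknown or untested is made for them only; others in the source may bear on it.

Measured compounds:
- compound 1, `Cn1ncc(Cl)c1-c1cc(C(=O)N[C@@H]2CN[C@H](CC(O)CO)C[C@H]2c2ccc(Cl)c(Cl)c2)oc1Cl`: 3.79 nM
- compound 2, `Cn1ncc(Cl)c1-c1cc(C(=O)N[C@@H]2CN[C@H](CCO)C[C@H]2c2ccc(F)c(F)c2)oc1Cl`: 0.98 nM
- compound 3, `Cn1ncc(Cl)c1-c1cc(C(=O)N[C@@H]2CN[C@H](CC(=O)NCC(O)CO)C[C@H]2c2ccc(Cl)c(Cl)c2)oc1Cl`: 3.13 nM

All three were tested in an assay for inhibition of RAC-alpha serine/threonine-protein kinase (Homo sapiens), read by HTRF, with a stated time of 1 h; a lower number here means a stronger inhibitor, a higher number a weaker inhibitor. Compound 3 stands second highest of the three numbers: its nearest neighbour is compound 1, and the two lie within the usual scatter of each other, while compound 2 gives a number that is clearly lower and sits beyond the scatter.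

The step to the unmeasured compound 4, `Cn1ncc(Cl)c1-c1cc(C(=O)N[C@@H]2CN[C@H](CCO)C[C@H]2c2ccc(Cl)c(Cl)c2)oc1Cl`, is hydroxymethyl in place of (2,3-dihydroxypropyl)carbamoyl on a saturated chain carbon bound to a saturated ring carbon. Compound 4 thus keeps the dichlorophenyl ring of compounds 1 and 3 and carries the 2-hydroxyethyl chain of compound 2.

For the measured compounds named here, only one measured step touches this chain: a 1.2-fold lower number from compound 1 to compound 3 (0.08 log units; within the scatter). It was within the scatter, so swapping one polar tail for another has so far changed little. Going by the values given here, no measured step reports the chain shortened on the dichlorophenyl series, and compound 2 differs from compound 4 in the aromatic ring as well, so its value is only a hint, not a direct comparison.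

On that basis the step from compound 3 to compound 4 is expected to be small, a 1.3-fold lower number from compound 3 to compound 4 (0.10 log units; within the scatter), with a lower number slightly favoured. Compound 4 is therefore estimated at 2.5 nM, with a range from 0.8 nM to 8 nM.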

Compound 4, half-maximal inhibitory concentration: 2.74 nM
Compound 4: middle estimate off by 1.1-fold (0.04 log units), on the low side; the range from low to high includes it.
By their numbers in this assay, from the lowest: compound 2; then compounds 4, 3 and 1 (each within the scatter of the next).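

In this assay, the chain on the saturated ring carbon turns out to matter little on the 3,4-dichlorophenyl series: replacing the long ((2,3-dihydroxypropyl)carbamoyl)methyl chain with 2-hydroxyethyl gives a 1.1-fold lower number from compound 3 to compound 4 (0.06 log units; within the scatter), and removing the hydroxymethyl from the chain of compound 1 gives a 1.4-fold lower number from compound 1 to compound 4 (0.14 log units; within the scatter), so both steps stay within the scatter. For the compounds shown here, the new compound also provides the first comparison that changes only the aromatic ring, since 3,4-dichlorophenyl in place of 3,4-difluorophenyl gives a 2.8-fold higher number from compound 2 to compound 4 (0.45 log units; beyond the scatter), a modest step but one beyond the scatter, unlike the two chain steps. No measurement shown here accounts for either finding.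

On these data alone, it remains open whether an amine or a carboxylic acid at the end of the chain would read the same as these hydroxyl-bearing chains, and whether a longer chain ending in a plain methyl would do so too. Going by these compounds alone, compound 2 is the only compound here with the 3,4-difluorophenyl ring, so it is also unknown whether the chain matters as little on that ring.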